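The source may report more compounds than this note shows. Statements on the series, on what has been measured and on what is new or still open speak of the compounds shown alone.

Series notes. All three measured compounds are weak in an assay on isolated protein for inhibition of interferon-induced, double-stranded RNA-activated protein kinase (Homo sapiens), read by luminescence, with a stated time of 10 min; a higher number here means a weaker inhibitor, a lower number a stronger inhibitor. Compound 1 `C=C1NNC(=O)/C1=N\Nc1ccc(S(N)(=O)=O)cc1` gives 11000 nM in this assay. Compound 2 `Nc1nc(Nc2ccc(OC(F)(F)F)cc2)c2nc[nH]c2n1` gives 20000 nM in this assay. Compound 3 `Cc1[nH]c2ccccc2c1-c1ccnc(NC(CO)C(C)C)n1` gives 50000 nM in this assay, the highest of the three numbers: the nearest is compound 2, whose number lies lower by a margin beyond the usual scatter, and the furthest is compound 1, lower by a larger margin, also beyond the scatter. No two of these compounds differ in one place only, so none of these gaps can be assigned to a single structural change.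

Compound 4 `Cc1[nH]c2ccccc2c1-c1ccnc(Nc2ccc(F)c(F)c2)n1` is not yet measured. Relative to compound 3 it carries 3,4-difluorophenyl in place of 1-(hydroxymethyl)-2-methylpropyl on a nitrogen on an aromatic ring. Among the compounds with values here, no measured pair in this set reports the effect of such a change, so the expectation rests on the general level of the series rather than on a precedent. The step from compound 3 to compound 4 in this assay is expected to be a 2.0-fold lower number from compound 3 to compound 4 (0.30 log units; within the scatter), a modest move toward a lower number, with the direction itself uncertain. For compound 4 a value of 25000 nM is estimated in this assay, within the range 6000 nM to 100000 nM.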

Compound 4, half-maximal inhibitory concentration: 1500 nM
Compound 4: middle estimate off by 17-fold (1.22 log units), on the high side, outside the stated range (below it).
By their numbers in this assay, from the lowest: compound 4; then compounds 1 and 2 (each within the scatter of the next); then compound 3.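

In this assay, the substituent on the nitrogen on the aromatic ring now has its first one-place comparison: 3,4-difluorophenyl in place of 1-(hydroxymethyl)-2-methylpropyl gives a 33-fold lower number from compound 3 to compound 4 (1.52 log units; beyond the scatter) on the shared core. Within the data shown here, the group on this nitrogen therefore has a large influence on the number, which the earlier compounds could not show, as no two of them differed in one place only. No measurement on hand accounts for the size of this step.

The swap changes an open chain bearing a hydroxymethyl into a fluorinated aromatic ring in one move, so the contributions of the ring, the fluorine atoms and the lost hydroxymethyl remain unseparated. A plain phenyl, a cyclohexyl or a benzyl on the same nitrogen would begin to divide the step between these parts.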